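Trimming a Chlorinated Chain to a Cyclopropyl Ring

The source may hold more compounds than are shown below. What is called first, only, known or untested is meant among the compounds shown, and "the series" means these compounds.

- compound 1 (`COc1ccc(CN(C(C)=O)c2cc(OC)c(OC)c(OC)c2)cc1O`): 79 nM measured
- compound 2 (`COc1ccc(CN(C(=O)CCCCCl)c2cc(OC)c(OC)c(OC)c2)cc1O`): 540 nM measured

In a functional assay on MGC-803 cells (Homo sapiens) for inhibition, read by MTT assay, with a stated time of 48 h (on this read-out higher numbers stand for weaker inhibition and lower numbers for stronger inhibition), compound 2 has the higher of the two numbers (540 nM), which makes it the weaker inhibitor of this pair. Compound 3 (`COc1ccc(CN(C(=O)C2CC2)c2cc(OC)c(OC)c(OC)c2)cc1O`) has not been measured yet. It differs from compound 2 by one group (cyclopropyl in place of 4-chlorobutyl on a carbonyl carbon), with cyclopropyl in place of 4-chlorobutyl on a carbonyl carbon.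

Among the measured compounds shown here, only one measured step bears on this change. That step is a 6.8-fold higher number from compound 1 to compound 2 (0.83 log units; beyond the scatter) and came with 3-chloropropyl in place of hydrogen on a saturated chain carbon bound to a carbonyl carbon. It was modest but beyond the scatter. Compound 3 loses that chain, although no ring has been measured at this place. A partial return towards compound 1 (79 nM) therefore seems likely. The expected change in this assay is a 2.7-fold lower number from compound 2 to compound 3 (0.43 log units; beyond the scatter) in size. The estimate for compound 3 is 200 nM (range 60 nM to 600 nM).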

Compound 3, half-maximal inhibitory concentration: 59 nM
Beside the measured number, compound 3's estimate is 3.4-fold (0.53 log units) above it; the measured number lies below the stated range.
By their numbers in this assay, from the lowest: compounds 3 and 1 (each within the scatter of the next); then compound 2.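

In this assay, putting cyclopropyl in place of 4-chlorobutyl on the carbonyl carbon gives a 9.2-fold lower number from compound 2 to compound 3 (0.96 log units; beyond the scatter) and so recovers the inhibition lost with the long chlorinated chain. Cyclopropyl in place of methyl at this same place gives a 1.3-fold lower number from compound 1 to compound 3 (0.13 log units; within the scatter) and leaves the two compounds indistinguishable, which shows that this position accepts a small ring as well as a methyl group. Nothing measured here explains why the chlorinated chain weakens inhibition while the ring does not.

The compounds shown do not separate the effect of the chlorine from that of the chain length, a question that a plain butyl chain could address. Going by these compounds, whether a larger ring such as cyclohexyl, or an amine at the end of the chain, would be accepted at this position also remains open.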